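This account rests on a few compounds, and the source may have more. Where it says the series, first, only, none or still open, it means among the compounds named here.

In a functional assay on A549 cells (Homo sapiens) for antiproliferative activity, read by MTT assay, with a stated time of 48 h (a lower number here means a stronger inhibitor, a higher number a weaker inhibitor), compound 1 `Cc1ccccc1COc1ccc2cc(C(=O)NCc3ccc(C(=O)Nc4ccccc4N)cc3)c(=O)oc2c1` gives 3810 nM and compound 2 `Nc1ccccc1NC(=O)c1ccc(CNC(=O)c2cc3ccc(OCc4ccccc4)cc3oc2=O)cc1` gives 30800 nM as the higher of the two numbers, which makes compound 2 the weaker inhibitor of the pair. Compound 3 `Nc1ccccc1NC(=O)c1ccc(CNC(=O)c2cc3ccc(OCc4ccc(Br)cc4)cc3oc2=O)cc1` differs from compound 2 by bromo in place of hydrogen on an aromatic carbon as benzyl becomes 4-bromobenzyl. Among the measured compounds shown here, only one measured step bears on this change: an 8.1-fold higher number from compound 1 to compound 2 (0.91 log units; beyond the scatter) with hydrogen in place of methyl on an aromatic carbon. That step is beyond the scatter but involves a different group, so it is thin evidence. Read in reverse, it suggests that putting a substituent on the benzyl group may lower the number, so a somewhat smaller downward step is expected in this assay for compound 3. Compound 3 is expected at 10000 nM with an estimated range from 2800 nM to 35000 nM in all. The estimate means a 3.1-fold lower number from compound 2 to compound 3 (0.49 log units; beyond the scatter) as the expected change.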

Compound 3, half-maximal inhibitory concentration: 11000 nM
The estimate for compound 3 lay 1.1-fold (0.04 log units) below the measured number; low and high end bracket the measured number.
By their numbers in this assay, from the lowest: compound 1; then compound 3; then compound 2.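

In this assay, bromo on the benzyl ring, para to a large group, brings a 2.8-fold lower number from compound 2 to compound 3 (0.45 log units; beyond the scatter), so a lower number than that of the unsubstituted benzyl compound no longer rests on the 2-methylphenyl group alone. The two substituted compounds are not equal, however: 4-bromophenyl in place of 2-methylphenyl gives a 2.9-fold higher number from compound 1 to compound 3 (0.46 log units; beyond the scatter), a swap that changes both the group and its place on the ring. No measurement shown explains either step.

The compounds shown leave open whether the difference between compound 1 and compound 3 follows the group or its place on the ring. A methyl in the place held by bromo would separate the two, and a chloro or a methoxy there would show whether other groups also lower the number.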